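Leaving-group variation on a shared aspartyl ketone core

The source may report more compounds than this note shows. Statements on the series, on what has been measured and on what is new or still open speak of the compounds shown alone.

Three compounds share one core and differ only in the group on a saturated chain carbon bound to a carbonyl carbon. Compound 1 is `CCOC(=O)c1c(C)noc1OCC(=O)[C@H](CC(=O)O)NC(=O)[C@@H](NC(=O)COc1cccc2ccccc12)C(C)C`. In a functional assay on Jurkat cells (Homo sapiens) for inhibition (on this read-out higher numbers stand for weaker inhibition and lower numbers for stronger inhibition), compound 1 returns only a limit, > 200000 nM. Compound 2 is `CC(C)[C@H](NC(=O)COc1cccc2ccccc12)C(=O)N[C@@H](CC(=O)O)C(=O)CSC1=NCCS1`. In this assay compound 2 likewise returns only a limit, > 200000 nM. Compound 3 is `CC(C)[C@H](NC(=O)COc1cccc2ccccc12)C(=O)N[C@@H](CC(=O)O)C(=O)CSc1nc2ccccc2o1`. Compound 3 stands at a limit as well, > 200000 nM, so its position on the numbers shown is not a number but the upper edge of this assay. This is the limit of > 200000 nM in this assay, at which 3 of the 3 values shown sit. Accordingly the steps a step that the two limits leave unreadable from compound 1 to compound 2, a step that the two limits leave unreadable from compound 1 to compound 3 and a step that the two limits leave unreadable from compound 2 to compound 3 carry no readable size and no direction.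

Compound 4 is `CC(C)[C@H](NC(=O)COc1cccc2ccccc12)C(=O)N[C@@H](CC(=O)O)C(=O)COc1cc(C(F)(F)F)ncn1`. It differs from compound 3 by (6-(trifluoromethyl)pyrimidin-4-yl)oxy in place of (1,3-benzoxazol-2-yl)sulfanyl on a saturated chain carbon bound to a carbonyl carbon. For the measured compounds named here, the steps that touch the same place, from compound 1 to compound 3 and from compound 2 to compound 3, are the ones that would bear on this change, yet both are unreadable, so no size of step in this assay can be derived from them, in either direction. Compound 4 is therefore expected, with low confidence, to sit near 200000 nM, in the range 10000 nM to 400000 nM. The expected step from compound 3 to compound 4 is a number no higher from compound 3 to compound 4 (the limit leaves the size open), a placeholder that the measurement must replace.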

Compound 4, half-maximal inhibitory concentration: > 200000 nM
Compound 4 gave a limit, no number; the forecaster's own chance of this, stated with the estimate: 65%; the middle value lies on the limit itself.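

In this assay compound 4 returns only a limit, > 200000 nM. No step linking compound 4 to compound 1, compound 2 or compound 3 can be read, and all four compounds sit at the same edge: the limit of > 200000 nM in this assay, at which 4 of the 4 values shown sit.

The compounds shown leave open whether any group at this place on the shared core gives a measurable value in this assay, and how these four groups rank.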